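This account rests on a few compounds, and the source may have more. Where it says the series, first, only, none or still open, it means among the compounds named here.

Compound 1 `NNC(=O)CSc1nnc(-c2ccncc2)o1`, compound 2 `O=C(CSc1nnc(-c2ccncc2)o1)N/N=C/c1cccc(C(F)(F)F)c1` and compound 3 `O=C(CSc1nnc(-c2ccncc2)o1)N/N=C/c1ccccc1F` share one core and differ only in what hangs from the hydrazide. In a functional assay on MCF7 cells (Homo sapiens) for cytotoxicity, read by MTT assay, with a stated time of 48 h (a lower number here means a stronger inhibitor, a higher number a weaker inhibitor), compound 1 gives 3260 nM, compound 2 gives 14600 nM, and compound 3 gives 21800 nM, the highest of the three numbers, close to compound 2 and well apart from compound 1. Compound 4 `COc1cc(/C=N/NC(=O)CSc2nnc(-c3ccncc3)o2)ccc1O` has not yet been measured in this assay. It differs from compound 3 by 4-hydroxy-3-methoxyphenyl in place of 2-fluorophenyl on a carbon with a double bond to nitrogen. For the measured compounds named here, with no step of this kind among the measured pairs, only a modest shift is expected, if any beyond the scatter, leaning towards a lower number: the step from compound 3 to compound 4 is estimated at a 1.8-fold lower number from compound 3 to compound 4 (0.26 log units; within the scatter). Compound 4 is therefore expected to give about 12000 nM, within 4000 nM to 40000 nM.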

Compound 4, half-maximal inhibitory concentration: 3780 nM
The estimate for compound 4 lay 3.2-fold (0.50 log units) above the measured number; the whole stated range lies above it.
By their numbers in this assay, from the lowest: compounds 1 and 4 (each within the scatter of the next); then compounds 2 and 3 (each within the scatter of the next).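

In this assay, for the compounds shown here, 4-hydroxy-3-methoxyphenyl in place of 2-fluorophenyl on a carbon with a double bond to nitrogen gives a 5.8-fold lower number from compound 3 to compound 4 (0.76 log units; beyond the scatter) and so shows, for the first time, that a change at this position can go beyond the scatter. The entering group carries one hydrogen-bond donor and two hydrogen-bond acceptors, while the leaving group carries none. No available evidence explains the step.

The hydroxy and methoxy groups enter together, so the step cannot be divided between them. Going by these compounds, how an amine or a carboxylic acid on this phenyl ring would read remains open.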